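The source may report more compounds than this note shows. Statements on the series, on what has been measured and on what is new or still open speak of the compounds shown alone.

Working notes on the series.

Three members of the series have been measured. Compound 3 `COc1ccc(-c2cc(C)c3ncc(CSCCc4ccccc4)n3c2)cc1` is the reference point for the step considered here, alongside compound 1 `Cc1cc(-c2ccccc2)cn2c(CSCCc3ccccc3)cnc12` and compound 2 `COc1cccc(-c2cc(C)c3ncc(CSCCc4ccccc4)n3c2)c1`. In an ADME assay on HEL cells (Homo sapiens) for cytotoxicity, with a stated time of 3 days (a higher number here means that more compound is tolerated, a lower number that less compound is tolerated), compound 1 gives 20 ug/mL. Compound 2 gives 20 ug/mL in this assay, and compound 3 gives 20 ug/mL. The steps between them are flat: no change at the digits printed from compound 1 to compound 2 (within the scatter), no change at the digits printed from compound 1 to compound 3 (within the scatter), and no change at the digits printed from compound 2 to compound 3 (within the scatter). Going by the values given here, compound 3 therefore stands level with compound 1 and compound 2 on the numbers so far, with nothing to set it apart.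

The unmeasured compound 4 `Cc1cc(-c2cccc([N+](=O)[O-])c2)cn2c(CSCCc3ccccc3)cnc12` differs from compound 3 as follows: 3-nitrophenyl in place of 4-methoxyphenyl on an aromatic carbon. The measured steps that bear on this change are those that altered the same aromatic position, namely adding a methoxy group (compound 1 to compound 3) or moving it (compound 2 to compound 3); both left this assay unchanged. Among the compounds with values here, no measured step introduces a nitro group, so that part of the change is untested. On the available evidence the expected step is no change at the digits printed from compound 3 to compound 4 (within the scatter), that is, none beyond the scatter. Compound 4 is accordingly estimated at 20 ug/mL in this assay, with an expected range of 10 ug/mL to 50 ug/mL.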

Compound 4, minimum cytotoxic concentration: >= 100 ug/mL
Compound 4 ended at the assay's limit; the forecaster's own chance of this, stated with the estimate: 10%; middle value at least 5.0-fold (0.69 log units) away from the limit.
By their numbers in this assay, from the lowest: compounds 1, 2 and 3 (each within the scatter of the next). At a limit, above all of these: compound 4.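

The aromatic carbon of the shared core that carries the aryl group, flat across hydrogen and methoxy on the phenyl ring, proves able to shift the read-out in this assay: the change to 3-nitrophenyl gives an at least 5.0-fold higher number from compound 3 to compound 4 (0.69 log units; beyond the scatter). The closest comparison is with the 3-methoxyphenyl of compound 2, where the two groups share one place on the phenyl ring and the exchange of nitro for methoxy gives an at least 5.0-fold higher number from compound 2 to compound 4 (0.69 log units; beyond the scatter), while nitro in place of hydrogen gives an at least 5.0-fold higher number from compound 1 to compound 4 (0.69 log units; beyond the scatter), so among these compounds only the nitro group goes with a shift and the place on the phenyl ring alone does not account for it. The value for compound 4 is a limit and not a number, so all three steps give only a lower bound on their size: the limit of >= 100 ug/mL in this assay, at which 1 of the 4 values shown sits.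

From the compounds shown here alone, whether the shift belongs to the nitro group alone or would also appear with an amine or a carboxylic acid at the same place on the phenyl ring remains open. The compounds shown also leave open whether 4-nitrophenyl would read like 3-nitrophenyl, and how far the true size of the step extends.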